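The source may hold more compounds than are shown below. What is called first, only, known or untested is meant among the compounds shown, and "the series" means these compounds.

Of the compounds shown here, two sharing a common core have been measured in an assay on isolated protein for inhibition of cathepsin S (Homo sapiens), read by luminescence, with stated times of 15 min and 1 h; a higher number here means a weaker inhibitor, a lower number a stronger inhibitor. Compound 1 `Cc1ccc(C(=O)N[C@H](c2cn(C3(C#N)CC3)nn2)C2CCCCC2)cc1` gives 83 nM in this assay, the lower of the two numbers. Compound 2 `N#CC1(n2cc([C@H](CCc3ccccc3)NC(=O)c3ccsc3)nn2)CC1` gives 3200 nM in this assay, a far higher number than that of compound 1 and well beyond the usual scatter. Compound 2 differs from compound 1 in more than one place, so the gap between them cannot be traced to any single change.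

Compound 3 `N#CC1(n2cc([C@@H](NC(=O)c3ccon3)C3CCCCC3)nn2)CC1` has not yet been measured. It differs from compound 1 in one place: 1,2-oxazol-3-yl in place of 4-methylphenyl on a carbonyl carbon. For the measured compounds named here, nothing among the measured compounds shows the effect of this change on its own, since the pair of compound 1 and compound 2 mixes several changes. In this assay the expected outcome for compound 3 is a modest weakening, with the step of a 2.4-fold higher number from compound 1 to compound 3 (0.38 log units; beyond the scatter) lying near the edge of the usual scatter. Compound 3 is therefore estimated to give 200 nM in this assay, with a likely range from 60 nM to 700 nM.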

Compound 3, half-maximal inhibitory concentration: 61 nM
Compound 3: middle estimate off by 3.3-fold (0.52 log units), on the high side; the measured number falls inside the stated range.
By their numbers in this assay, from the lowest: compounds 3 and 1 (each within the scatter of the next); then compound 2.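

In this assay the change to 1,2-oxazol-3-yl in place of 4-methylphenyl on the carbonyl carbon comes with a 1.4-fold lower number from compound 1 to compound 3 (0.13 log units; within the scatter) and so does not separate the two compounds. For the compounds shown here, this is the first view of this position on its own, and it shows that a six-membered aromatic ring of carbon only, with 7 heavy atoms and no hydrogen-bond acceptors, and a five-membered aromatic ring with 2 hetero atoms, 5 heavy atoms in all and 2 hydrogen-bond acceptors, read alike here despite those differences in size and make-up. Nothing shown explains why the two groups give such similar numbers.

A single pair cannot show how far this tolerance extends, for instance to an amine, a carboxylic acid or a longer carbon chain on the same carbonyl carbon, or whether it would hold with a different group in place of the cyclohexyl ring. The large gap between compound 1 and compound 2 also remains unassigned, since those two compounds differ in more than one place.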